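Chain amine swap on a quinoline N-oxide quinone core

The compounds below may be only part of what the source reports. "The series", "measured", "known", "first", "only" and "open" are said of these compounds alone.

Compounds measured so far in a functional assay on SH-SY5Y cells (Homo sapiens) for cytotoxicity, read by MTT assay, with a stated time of 72 h; on this read-out lower numbers stand for stronger inhibition and higher numbers for weaker inhibition:
Compound 1 `O=C1c2c[n+]([O-])c3ccccc3c2C(=O)c2[nH]c3ccccc3c21` gives 1380 nM.
Compound 2 `O=C1c2c[n+]([O-])c3ccccc3c2C(=O)c2c1c1ccccc1n2CCCCN1CCNCC1` gives 1240 nM.
Compound 3 `CCCN1CCN(CCCCn2c3c(c4ccccc42)C(=O)c2c[n+]([O-])c4ccccc4c2C3=O)CC1` gives 3970 nM.

Compound 3 stands highest of the three numbers, its nearest neighbour being compound 1 and its furthest compound 2, both steps beyond the scatter. The two measured steps were a 1.1-fold lower number from compound 1 to compound 2 (0.05 log units; within the scatter) and a 3.2-fold higher number from compound 2 to compound 3 (0.51 log units; beyond the scatter), so adding the chain itself changed little while adding propyl to the amine nitrogen in the ring raised the number modestly.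

Compound 4 `CN(C)CCCCCn1c2c(c3ccccc31)C(=O)c1c[n+]([O-])c3ccccc3c1C2=O` differs from compound 3 as follows: (dimethylamino)methyl in place of 4-propylpiperazin-1-yl on a saturated chain carbon, four bonds along the chain from an aromatic nitrogen. Among the measured compounds shown here, no measured step matches this change directly; only the step from compound 2 to compound 3 touches the same amine nitrogen, and it replaced hydrogen rather than removing the ring. The size of step in this assay from compound 3 to compound 4 is therefore uncertain, and a number between those of compound 2 and compound 3 is expected, a step of a 1.6-fold lower number from compound 3 to compound 4 (0.20 log units; within the scatter). Compound 4 is expected to give about 2500 nM, between 1000 nM and 6300 nM.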

Compound 4, half-maximal inhibitory concentration: 370 nM
For compound 4 the middle estimate is 6.8-fold (0.83 log units) above the measured one, and the stated range ends above it.
By their numbers in this assay, from the lowest: compound 4; then compounds 2 and 1 (each within the scatter of the next); then compound 3.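

In this assay, among the compounds shown here, the earlier compounds showed the chain changing little, but the group at its end proves able to move the number a long way: (dimethylamino)methyl in place of 4-propylpiperazin-1-yl gives an 11-fold lower number from compound 3 to compound 4 (1.03 log units; beyond the scatter) on this saturated chain carbon, and in place of piperazin-1-yl it gives a 3.4-fold lower number from compound 2 to compound 4 (0.53 log units; beyond the scatter) there. With 5-(dimethylamino)pentyl on the aromatic nitrogen, the result is a 3.7-fold lower number from compound 1 to compound 4 (0.57 log units; beyond the scatter) and so a real gain over the core of compound 1, which compound 2 did not show. No measurement here explains these steps.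

The compounds shown leave open whether the ring or the added chain carbon drives the change, since a 4-(dimethylamino)butyl chain would separate the two. They also leave open whether a diethylamino or a morpholine group at the chain end would behave like compound 4.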